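Cyano to Methoxy: Expected Cytotoxicity of Compound 4

The source may hold more compounds than are shown below. What is called first, only, known or untested is meant among the compounds shown, and "the series" means these compounds.

Compound 1, `O=c1c(OCc2ccccc2Cl)c(-c2ccccc2)oc2cc(O)cc(O)c12`: > 100000 nM in an ADME assay on Huh-5-2 cells (Homo sapiens) for cytotoxicity, read by WST assay, with a stated time of 3 days; on this read-out higher numbers stand for lower toxicity in this test and lower numbers for higher toxicity in this test (a limit)
Compound 2, `O=c1c(OCc2ccccc2Br)c(-c2ccccc2)oc2cc(O)cc(O)c12`: 12000 nM in this assay
Compound 3, `N#Cc1ccccc1COc1c(-c2ccccc2)oc2cc(O)cc(O)c2c1=O`: > 100000 nM in this assay (a limit)

Compound 3 has no number of its own in this assay; its value is a limit of the assay. The same is true of compound 1, so that (the limit of > 100000 nM in this assay, at which 2 of the 3 values shown sit). Only compound 2 gives a real number. Going from compound 2 to compound 3 the reading moved an at least 8.3-fold higher number from compound 2 to compound 3 (0.92 log units; beyond the scatter), a change that stands out from the scatter. Between compound 1 and compound 3 the change is a step that the two limits leave unreadable from compound 1 to compound 3. Both of these compounds sit at the same limit.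

Compound 4, `COc1ccccc1COc1c(-c2ccccc2)oc2cc(O)cc(O)c2c1=O`, differs from compound 3 in one place: methoxy in place of cyano on an aromatic carbon. Among the compounds with values here, none of the measured steps involves a methoxy group, so there is no direct guide. What is known is that two of the three measured compounds sit at the limit, and compound 3 is one of them. The step to compound 4 is therefore expected to be small, an at least 1.4-fold lower number from compound 3 to compound 4 (0.15 log units; that floor lies within the scatter), with a fair chance that the assay again reports only a limit. Compound 4 is expected to give 70000 nM in this assay, estimated between 15000 nM and 300000 nM.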

Compound 4, half-maximal cytotoxic concentration: 53000 nM
The estimate for compound 4 lay 1.3-fold (0.12 log units) above the measured number; the range from low to high includes it.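

The methoxy group gives a second real number at this place on the ring, so bromo can now be compared directly with another group: a 4.4-fold higher number from compound 2 to compound 4 (0.65 log units; beyond the scatter). In this assay, this means that compound 4 reads as less toxic than the bromo compound, although its number falls within the measurable range rather than at the limit, and the other two steps can be stated only as floors: an at least 1.8-fold lower number from compound 3 to compound 4 (0.27 log units; that floor lies within the scatter), and an at least 1.8-fold lower number from compound 1 to compound 4 (0.27 log units; that floor lies within the scatter). Those floors do not show a real difference between methoxy and either cyano or chloro, and compound 1 and compound 3 still have no number of their own: the limit of > 100000 nM in this assay, at which 2 of the 4 values shown sit.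

From the compounds shown here alone, it remains open how far the true values of compound 1 and compound 3 lie from that of compound 4, so no order can be set among methoxy, cyano and chloro. Going by these compounds, it is also open whether the lower number of compound 2 is particular to bromo, and how this place would respond to an amine, a carboxylic acid or a longer chain such as ethoxy.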